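Swapping a Methyl for a Hydroxy on the Aryl Arm

The compounds below may be only part of what the source reports. "The series", "measured", "known", "first", "only" and "open" are said of these compounds alone.

Compound 2, `CC1=CC[C@@H]([C@@](C)(O)CCCC(C)(C)NC(=S)N/N=C\c2ccc(C)cc2)CC1`, carries a thiosemicarbazone arm ending in a 4-methylphenyl group. In a functional assay on NCI-H460 cells (Homo sapiens) for cytotoxicity, read by sulforhodamine B assay (on this read-out lower numbers stand for stronger inhibition of growth and higher numbers for weaker inhibition of growth), compound 2 gives 10100 nM. That is the higher of the two numbers recorded, but only by a margin that stays within the scatter: compound 1, `CC1=CC[C@@H]([C@@](C)(O)CCCC(C)(C)NC=S)CC1`, which lacks the aryl arm altogether, gives 9250 nM in this assay, so the two cannot be told apart.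

Compound 3, `CC1=CC[C@@H]([C@@](C)(O)CCCC(C)(C)NC(=S)N/N=C\c2ccc(O)cc2)CC1`, differs from compound 2 in one place: hydroxy in place of methyl on an aromatic carbon. Among the compounds with values here, no measured pair shows what this exchange does here. Within the data shown here, since adding or removing the whole aryl arm between compound 1 and compound 2 left the numbers within the scatter, the single change on that arm is expected to move the number little, with no direction favoured. The step from compound 2 to compound 3 is expected to be a 1.1-fold lower number from compound 2 to compound 3 (0.05 log units; within the scatter), and compound 3 is expected to give about 9000 nM, within a range of 3000 nM to 27000 nM.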

Compound 3, concentration for 50% growth inhibition: 1460 nM
Compound 3: middle estimate off by 6.2-fold (0.79 log units), on the high side, outside the stated range (below it).
By their numbers in this assay, from the lowest: compound 3; then compounds 1 and 2 (each within the scatter of the next).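

In this assay the exchange of methyl for hydroxy brings a 6.9-fold lower number from compound 2 to compound 3 (0.84 log units; beyond the scatter) and so marks this aromatic carbon as a place where a small change counts. The close numbers of compound 1 and compound 2 gave no hint of this, since a 4-methylphenyl arm and no arm at all could not be told apart, whereas compound 3 shows that the group at the end of the arm can shift growth inhibition well beyond the scatter. No measurement here accounts for the shift, so its cause remains unknown.

Going by these compounds, whether the shift belongs to hydroxy alone stays open, as an amine, a methoxy group or a carboxylic acid on the same carbon could read either way. This single pair also cannot tell whether the exchange would do the same on an arm with a longer chain.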